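Changing the group on the ether chain carbon

The source may hold more compounds than are shown below. What is called first, only, known or untested is meant among the compounds shown, and "the series" means these compounds.

In a functional assay (blood) for inhibition, with Homo sapiens as the target (on this read-out lower numbers stand for stronger inhibition and higher numbers for weaker inhibition), compound 1 (`COc1ccc2nc(COc3ccc4c(c3)c(SC(C)(C)C)c(CC(C)(C)C(=O)O)n4Cc3ccc(Cl)cc3)sc2c1`) gives 670 nM and compound 2 (`C[C@@H](COc1ccc2c(c1)c(SC(C)(C)C)c(CC(C)(C)C(=O)O)n2Cc1ccc(Cl)cc1)c1ccccn1`) gives 280 nM, the lower of the two numbers. Compound 3 (`CC(C)(C)Sc1c(CC(C)(C)C(=O)O)n(Cc2ccc(Cl)cc2)c2ccc(OCc3cnccn3)cc12`) carries this change from compound 2: pyrazin-2-yl in place of 1-(pyridin-2-yl)ethyl on a saturated chain carbon bound to an oxygen on an aromatic ring. Within the data shown here, the only measured step at this place is a 2.4-fold lower number from compound 1 to compound 2 (0.38 log units; beyond the scatter), a modest one, and the group entering here appears in neither measured compound. A step of similar modest size towards a higher number is therefore expected in this assay, the estimated 1.6-fold higher number from compound 2 to compound 3 (0.21 log units; within the scatter). For compound 3 the estimated value is 450 nM, with an expected range of 150 nM to 1300 nM.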

Compound 3, half-maximal inhibitory concentration: 400 nM
Compound 3: middle estimate off by 1.1-fold (0.05 log units), on the high side; low and high end bracket the measured number.
By their numbers in this assay, from the lowest: compounds 2, 3 and 1 (each within the scatter of the next, the first and the last beyond it).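

On the saturated chain carbon bound to an oxygen on an aromatic ring, pyrazin-2-yl in place of 1-(pyridin-2-yl)ethyl gives a 1.4-fold higher number from compound 2 to compound 3 (0.15 log units; within the scatter), and pyrazin-2-yl in place of 6-methoxy-1,3-benzothiazol-2-yl gives a 1.7-fold lower number from compound 1 to compound 3 (0.22 log units; within the scatter). Compound 3 therefore stays within the scatter of both, while the step between the other two lies beyond it. Losing the defined stereocentre in the step to compound 3 brings no change beyond the scatter.

On these data alone, whether an amine or a carboxylic acid at this place would move the number beyond the scatter stays open. The reason for these steps also stays open, as no measurement here bears on it.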